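Acetylpiperidine amide series, cytotoxicity: compound 3 pending

The source may report more compounds than this note shows. Statements on the series, on what has been measured and on what is new or still open speak of the compounds shown alone.

Measured so far:
compound 1 `CC(=O)N1CCC(C(=O)N(CCCN2CCN(Cc3ccc(C#N)cc3)CC2)c2ccc(C)c(Cl)c2)CC1`: > 100000 nM
compound 2 `CC(=O)N1CCC(C(=O)N(CCCN2CCN(c3ccccn3)CC2)c2ccc(C)c(Cl)c2)CC1`: > 58300 nM

In an ADME assay (Homo sapiens) for cytotoxicity (a lower number here means that less compound is tolerated, a higher number that more compound is tolerated), compound 2 gives only a limit, > 58300 nM. Compound 1 likewise sits at a limit in this assay, > 100000 nM. The step that the two limits leave unreadable from compound 1 to compound 2 is therefore not readable; both ends rest on limits (the limit of > 100000 nM in this assay, at which 1 of the 2 values shown sits, (the limit of > 58300 nM in this assay, at which 1 of the 2 values shown sits)). Compound 3 `CC(=O)N1CCC(C(=O)N(CCCN2CCN(Cc3ccc(Cl)nc3)CC2)c2ccc(C)c(Cl)c2)CC1` differs from compound 2 by (6-chloropyridin-3-yl)methyl in place of pyridin-2-yl on an amine nitrogen in a ring. Within the data shown here, the one measured step bearing on this position gives no readable size, so no change beyond the scatter is expected. The expected step that the limit leaves unreadable from compound 2 to compound 3 is none beyond the scatter. Compound 3 is estimated at 80000 nM, within 30000 nM to 200000 nM, most likely reported again as a limit.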

Compound 3, half-maximal cytotoxic concentration: > 53100 nM
Compound 3 gave a limit, no number; the forecaster's own chance of this, stated with the estimate: 70%; the middle value lies beyond the limit too.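

In this assay, among these compounds, compound 1, compound 2 and compound 3 each give only a limit, and no step among them can be read. The compounds shown leave open each actual half-maximal cytotoxic concentration and whether the group on the amine nitrogen in the ring shifts it.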